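Hydroxymethyl to methyl on the side chain of compound 3

This account rests on a few compounds, and the source may have more. Where it says the series, first, only, none or still open, it means among the compounds named here.

Compound 3 `Cc1cc(-c2noc(C3CC3)n2)cc(C)c1OCCCc1cc(CO)no1` has been run in an in vitro ADME assay on microsomes from liver (Simiiformes) (a lower number here means that the compound disappears faster, a higher number that the compound lasts longer), where compound 3 gives > 2.5 h, a limit of the assay and not a number. Compound 1 `Cc1cc(-c2noc(C(F)(F)F)n2)cc(C)c1OCCCc1cc(CO)no1` sits at the same limit: in this assay compound 1 gives > 2.5 h. Compound 2 `Cc1ccc(CCCOc2c(C)cc(-c3noc(C(F)(F)F)n3)cc2C)cn1` gives 1.97 h in this assay. The step of an at least 1.2-fold lower number from compound 1 to compound 2 (0.10 log units; that floor lies within the scatter) exchanges the chain end, 6-methylpyridin-3-yl in place of 3-(hydroxymethyl)-1,2-oxazol-5-yl on a saturated chain carbon, three bonds along the chain from an oxygen on an aromatic ring; the step that the two limits leave unreadable from compound 1 to compound 3 puts cyclopropyl in place of trifluoromethyl on an aromatic carbon. Because two of the three values sit at the limit of > 2.5 h in this assay, at which 2 of the 3 values shown sit, neither step can be read beyond its floor.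

Compound 4 `Cc1cc(CCCOc2c(C)cc(-c3noc(C4CC4)n3)cc2C)on1` differs from compound 3 in one place: hydrogen in place of hydroxy on a saturated chain carbon bound to an aromatic carbon. Read one bond further out, hydroxymethyl becomes methyl, so 3-(hydroxymethyl)-1,2-oxazol-5-yl becomes 3-methyl-1,2-oxazol-5-yl. Within the data shown here, no measured step touches the hydroxy itself; the nearest comparison removes the whole chain-end ring and stays within the scatter. For compound 4 a step of a number no higher from compound 3 to compound 4 (the limit leaves the size open) is therefore expected, none beyond the scatter, and the most likely outcome is another limit. The estimate for compound 4 in this assay is 2.5 h, between 1.2 h and 5 h.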

Compound 4, half-life: 2.23 h
Estimate against measurement, compound 4: 1.1-fold (0.05 log units) above; the range from low to high includes it.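

In this assay, the hydroxy on the saturated chain carbon bound to an aromatic carbon is now probed directly, and the exchange for hydrogen gives an at least 1.1-fold lower number from compound 3 to compound 4 (0.04 log units; that floor lies within the scatter). Among the cyclopropyl compounds shown, compound 4 alone gives a number rather than a limit, so the 3-methyl-1,2-oxazol-5-yl chain end provides the first readable reference for this part of the series. The change can be read only as a floor that stays within the scatter, and its true size stays open because compound 3 sits at a limit of the assay: the limit of > 2.5 h in this assay, at which 2 of the 4 values shown sit.

On these data alone, the hydroxymethyl group therefore cannot yet be assigned any contribution to the half-life, in either direction, and the pairing of trifluoromethyl with the 3-methyl-1,2-oxazol-5-yl chain end remains open. As far as these compounds go, it is also open how a carboxylic acid or an amine in place of the hydroxy at this saturated chain carbon would read in this assay, and whether either would give a number or another limit.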